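Halogen Swap on the Phenyl Attached to the Saturated Ring

This account rests on a few compounds, and the source may have more. Where it says the series, first, only, none or still open, it means among the compounds named here.

Of the compounds shown here, three have been measured in a functional assay on CHO cells for positive allosteric modulation of metabotropic glutamate receptor 2 (Homo sapiens), with a stated time of 30 min; on this read-out higher numbers stand for larger maximal responses and lower numbers for smaller maximal responses. Compound 1 `CC(C)CCn1ccc(-c2ccccc2)c(C#N)c1=O` gives 135% in this assay. Compound 2 `N#Cc1c(N2CCC(c3ccccc3)CC2)ccn(CCCC(F)(F)F)c1=O` gives 302%. Compound 3 `N#Cc1c(N2CCC(c3ccccc3Cl)CC2)ccn(CC2CC2)c1=O` gives 259%. On these numbers compound 3 stands second of the three: compound 2 lies above it by a gap beyond the usual scatter, and compound 1 lies below it by a larger gap that is also beyond the scatter. Compound 2 and compound 3 thus both sit well above compound 1, though they differ from it and from each other in more than one place, so no single change can be read out of their values.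

Compound 4 `N#Cc1c(N2CCC(c3c(F)cccc3F)CC2)ccn(CC2CC2)c1=O` has not yet been measured. It differs from compound 3 in one place: 2,6-difluorophenyl in place of 2-chlorophenyl on a saturated ring carbon. For the measured compounds named here, no measured pair differs only in this way, so there is no measured step to lean on, and the prior is that such a change leaves the maximal response roughly where it is. Compound 4 is therefore expected to give about 250%, with a range from 180% to 320%. The expected step of a number 9 percentage points lower from compound 3 to compound 4 (within the scatter) is estimated to be small, not clearly beyond the scatter in either direction.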

Compound 4, largest response reached (Emax), in percent of the reference or control that the assay uses: 291%
For compound 4 the middle estimate is 41 percentage points below the measured one; the measured number falls inside the stated range.
By their numbers in this assay, from the lowest: compound 1; then compound 3; then compound 4; then compound 2.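

In this assay, for the compounds shown here, the change from 2-chlorophenyl to 2,6-difluorophenyl on a saturated ring carbon, three ring bonds from the ring nitrogen, gives the first step that can be read at a single place: a number 32 percentage points higher from compound 3 to compound 4 (beyond the scatter). This shows that the maximal response is sensitive to the substitution on this phenyl, even though 2-chlorophenyl with its 7 heavy atoms and 2,6-difluorophenyl with its 8 heavy atoms both have 0 hydrogen-bond donors, 0 hydrogen-bond acceptors and no net charge. Nothing in the available data explains why this exchange raises the response.

The compounds shown leave open whether a phenyl with a methoxy group or a bromine atom in place of these halogens, with the rest of compound 4 unchanged, would hold the response at this level or move it further. They also leave open whether the same exchange would give a step of similar size on a compound carrying the trifluorinated chain of compound 2 on the ring nitrogen.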